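The source may report more compounds than this note shows. Statements on the series, on what has been measured and on what is new or still open speak of the compounds shown alone.

Series notes. Within the data shown here, in a toxicity assay on HeLa cells (Homo sapiens) for cytotoxicity, read by MTT assay, with a stated time of 24 h (on this read-out higher numbers stand for weaker inhibition and lower numbers for stronger inhibition), compound 3 `Cc1ncc([N+](=O)[O-])n1CC(O)CSC(=S)N1CCN(c2cccc(Cl)c2)CC1` gives 1080000 nM, the only number among the three measured compounds. Compound 1 `CCN1CCN(C(=S)SCC(O)Cn2c([N+](=O)[O-])cnc2C)CC1` gives > 5000000 nM, which is a limit of this assay and not a number. Compound 2 `COc1ccccc1N1CCN(C(=S)SCC(O)Cn2c([N+](=O)[O-])cnc2C)CC1` likewise gives > 5000000 nM, a limit. Both sit at the limit of > 5000000 nM in this assay, at which 2 of the 3 values shown sit. Among the measured compounds shown here, the steps of an at least 4.6-fold lower number from compound 1 to compound 3 (0.66 log units; beyond the scatter) and an at least 4.6-fold lower number from compound 2 to compound 3 (0.66 log units; beyond the scatter) mark compound 3 as the one compound with a readable number; the step that the two limits leave unreadable from compound 1 to compound 2 cannot be read. Compound 4 `Cc1ncc([N+](=O)[O-])n1CC(O)CSC(=S)N1CCN(c2cccc(Cl)c2Cl)CC1` differs from compound 3 by chloro in place of hydrogen on an aromatic carbon; read one bond further out, 3-chlorophenyl becomes 2,3-dichlorophenyl. For the measured compounds named here, no measured step adds a chloro to an aryl ring that already carries one; the nearest point of comparison is an at least 4.6-fold lower number from compound 2 to compound 3 (0.66 log units; beyond the scatter), where the chlorophenyl compound gave the lower number. A step in this assay from compound 3 to compound 4 within the scatter, or at most modestly lower, is expected. For compound 4 the estimate is 700000 nM, with a range from 300000 nM to 2000000 nM. The expected step is a 1.5-fold lower number from compound 3 to compound 4 (0.19 log units; within the scatter).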

Compound 4, half-maximal inhibitory concentration: 1000000 nM
Beside the measured number, compound 4's estimate is 1.4-fold (0.15 log units) below it; low and high end bracket the measured number.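

In this assay, a second chloro on the aromatic ring, ortho to a chloro group, gives a 1.1-fold lower number from compound 3 to compound 4 (0.03 log units; within the scatter), so this position accepts the added chlorine with no change beyond the scatter. The 2,3-dichlorophenyl group also keeps a readable number, with an at least 5.0-fold lower number from compound 2 to compound 4 (0.69 log units; beyond the scatter) and an at least 5.0-fold lower number from compound 1 to compound 4 (0.69 log units; beyond the scatter), so both chlorinated aryl compounds now separate from the 2-methoxyphenyl and ethyl compounds. Those two compounds remain at a limit of the assay, not at a number: the limit of > 5000000 nM in this assay, at which 2 of the 4 values shown sit.

As far as these compounds go, the step between those two limit compounds cannot be read, so the order of the 2-methoxyphenyl and ethyl groups stays unknown. From the compounds shown here alone, whether an amine or a carboxylic acid at this place on the aromatic ring would shift the number away from that of the chloro compounds stays open.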